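A few compounds are considered here, and "the series" means these few. Any claim that something is new, unique, unknown or untested is made for them only; others in the source may bear on it.

Compound 1 `CCCCCCNc1ccc([N+](=O)[O-])cc1S(N)(=O)=O`: < 0.0834 h (a limit of the assay)
Compound 2 `CCCCCCNc1ccc(C(=O)O)cc1S(N)(=O)=O`: > 1 h (a limit of the assay)
Compound 3 `CCCCCCCCNc1ccc(C(=O)O)cc1S(N)(=O)=O`: 0.3 h

In an ADME assay on microsomes from liver (Mus musculus) for metabolic stability, tested at 5 uM (a higher number here means that the compound lasts longer, a lower number that the compound disappears faster), compound 2 gives > 1 h, which is a limit of the assay and not a number. As far as these compounds go, its steps to the other two compounds are both beyond the scatter, so it lasts longest of the three, although its exact value stays open.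

Compound 4 `CCCCCCNc1ccc(C(=O)O)cc1S(=O)(=O)N(C)C` keeps the rest of compound 2 but has dimethylamino in place of amino on a sulfonyl sulfur. Going by the values given here, no measured step changes this group. Carboxy in place of nitro gave an at least 11-fold higher number from compound 1 to compound 2 (1.07 log units; beyond the scatter), a large step, but at a different place. The closer guide is ethyl in place of hydrogen on a saturated chain carbon, which gave an at least 3.3-fold lower number from compound 2 to compound 3 (0.52 log units; beyond the scatter), since that change also adds carbon. On the evidence of compound 3 at 0.3 h, a modest fall is expected in this assay, and the expected step is an at least 2.5-fold lower number from compound 2 to compound 4 (0.39 log units; beyond the scatter). For compound 4 the estimated half-life is 0.4 h, with an expected range from 0.12 h to 1.2 h.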

Compound 4, half-life: 0.283 h
Beside the measured number, compound 4's estimate is 1.4-fold (0.15 log units) above it; measured number inside the range.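

In this assay, the place on the sulfonyl sulfur proves sensitive: dimethylamino in place of amino gives an at least 3.5-fold lower number from compound 2 to compound 4 (0.54 log units; beyond the scatter). Going by these compounds alone, the earlier steps changed nitro to carboxy and added ethyl to the chain, so this is the first sign that the sulfamoyl group also affects how long these compounds last, and the step lies beyond the usual scatter. Compound 2 stands at a limit of the assay, so the full size of this step stays open: the limit of > 1 h in this assay, at which 1 of the 4 values shown sits.

The compounds shown cannot separate the effect of removing the hydrogens on this nitrogen from that of adding carbon there. They also leave open how methylamino, with a single methyl on that nitrogen, or a cyclic amine such as pyrrolidine would behave at this place.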